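Phenyl to 4-bromophenyl on compound 1

A few compounds are considered here, and "the series" means these few. Any claim that something is new, unique, unknown or untested is made for them only; others in the source may bear on it.

Working notes on three measured compounds and one unmeasured compound. Compound 1 (`c1ccc(-c2ccnc3c2c(-c2ccccc2)nn3-c2ccccc2)cc1`) gives 3210 nM in a functional assay on HepG2 cells (Homo sapiens) for inhibition, read by MTT assay, with a stated time of 48 h (a lower number here means a stronger inhibitor, a higher number a weaker inhibitor), the second highest of the three numbers. Compound 3 (`Cc1ccc(C(=O)C=CNc2cc(-c3ccccc3)nn2-c2ccccc2)cc1`) gives the highest number, 7320 nM. Compound 2 (`COc1ccc(-c2nc3c(c(-c4ccccc4)nn3-c3ccccc3)c(-c3ccc(N4CCN(C)CC4)cc3)c2C#N)cc1`) gives the lowest, 1330 nM. Both gaps to compound 1 lie beyond the scatter.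

Compound 4 (`Brc1ccc(-c2ccnc3c2c(-c2ccccc2)nn3-c2ccccc2)cc1`) follows from compound 1 by one change, bromo in place of hydrogen on an aromatic carbon, para to a large group. For the measured compounds named here, no two measured compounds differ in one place, so the series gives no direct measure of this change. Compound 2 and compound 3 each differ from compound 1 in more than one place and cannot size it.

The expected step, a 1.3-fold lower number from compound 1 to compound 4 (0.11 log units; within the scatter), is small, toward a lower number and within the scatter. Compound 4 is estimated at 2500 nM, with an expected range of 1000 nM to 6500 nM.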

Compound 4, half-maximal inhibitory concentration: 49900 nM
Beside the measured number, compound 4's estimate is 20-fold (1.30 log units) below it; measured number above the stated range.
By their numbers in this assay, from the lowest: compound 2; then compound 1; then compound 3; then compound 4.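

Phenyl to 4-bromophenyl on compound 1 gives a 16-fold higher number from compound 1 to compound 4 (1.19 log units; beyond the scatter) in this assay, the first direct reading of any single change in this series. The aromatic carbon para to a large group is therefore not a neutral place for bromo: one added heavy atom, with no ring, no charge and no hydrogen-bond donor or acceptor, is enough to produce a large step toward a weaker inhibitor. The size of the step shows how sensitive this assay can be to a change at this place on the core of compound 1, but no measurement here accounts for it.

As far as these compounds go, whether the step belongs to bromo itself or to any group on this carbon remains open, as fluoro, chloro, methoxy, an amine or a carboxylic acid in the same place would separate those readings. The same bromo on the other phenyl rings of compound 1 would show whether the effect is specific to this ring.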